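The compounds below may be only part of what the source reports. "The series", "measured", "known", "first", "only" and "open" are said of these compounds alone.

Measured in a functional assay on RAW264.7 cells (Mus musculus) for inhibition, read by Griess assay, with stated times of 3 h and 24 h; a lower number here means a stronger inhibitor, a higher number a weaker inhibitor:
Compound 1 `C=C1CCC2[C@](C)(CO)[C@H](O)CC[C@@]2(C)[C@@H]1CCn1ccc(=O)[nH]c1=O`: > 100000 nM, a limit
Compound 2 `C=C1CCC2[C@](C)(CO)[C@H](O)CC[C@@]2(C)[C@@H]1CCn1cncn1`: > 100000 nM, a limit
Compound 3 `C=C1CCC2[C@](C)(CO)[C@H](O)CC[C@@]2(C)[C@@H]1CCOc1ccc(Br)cc1`: 40300 nM

Compound 3 alone gives a number, 40300 nM. Compounds 1 and 2 stand at the limit of > 100000 nM in this assay, at which 2 of the 3 values shown sit. Compound 4 `C=C1CCC2[C@](C)(CO)[C@H](O)CC[C@@]2(C)[C@@H]1CCOC(=O)c1ccccc1` differs from compound 3 thus: benzoyl in place of 4-bromophenyl on an oxygen on a saturated carbon. In words, benzoyl stands in place of 4-bromophenyl on an oxygen on a saturated carbon. Within the data shown here, two measured steps bear on this, an at least 2.4-fold lower number from compound 1 to compound 3 (0.39 log units; beyond the scatter) and an at least 2.4-fold lower number from compound 2 to compound 3 (0.39 log units; beyond the scatter), each at least modest. Compound 4 keeps the six-membered aromatic ring of carbon only found in compound 3 (40300 nM), so no step beyond the scatter is expected in this assay. For compound 4 a limit remains possible. The expected step is a 1.1-fold higher number from compound 3 to compound 4 (0.05 log units; within the scatter). For compound 4 the estimated value is 45000 nM, with an expected range of 15000 nM to 100000 nM.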

Compound 4, half-maximal inhibitory concentration: > 100000 nM
Compound 4: a limit, no number (the forecaster's own chance of this, stated with the estimate: 35%); at least 2.2-fold (0.34 log units) between middle value and limit.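

In this assay, keeping the aromatic ring of carbon only does not by itself keep the measurable activity at this position: benzoyloxy in place of 4-bromophenoxy gives an at least 2.4-fold higher number from compound 3 to compound 4 (0.39 log units; beyond the scatter). For compound 4, > 100000 nM is a limit. The steps from compound 1 and from compound 2 to compound 4 cannot be read.

Among these compounds, whether any group on this oxygen improves on 4-bromophenoxy stays open, as only one compound gives a number: the limit of > 100000 nM in this assay, at which 3 of the 4 values shown sit. From the compounds shown here alone, how phenoxy without the bromine, an amine or a longer chain would read in this assay is also open.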